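The source may report more compounds than this note shows. Statements on the series, on what has been measured and on what is new or still open speak of the compounds shown alone.

Among the measured compounds shown here, only two compounds have been tested so far in a functional assay on MCF7 cells (Homo sapiens) for cytotoxicity, read by MTT assay, with a stated time of 72 h; a higher number here means a weaker inhibitor, a lower number a stronger inhibitor. Compound 1 `O=C1CS/C(=N\c2csc(-c3ccc(Cl)cc3)c2)N1` gives only a limit of the assay, > 50000 nM, and not an exact number. For the measured compounds named here, compound 2 `CN(C)c1ccc(/C=C2\S/C(=N\c3csc(-c4ccc(Cl)cc4)c3)NC2=O)cc1` gives 400 nM, the only exact number available, so it is the sole reference point for what follows.

Compound 3 `O=C1N/C(=N/c2csc(-c3ccc(Cl)cc3)c2)S/C1=C\c1ccc(F)cc1` matches compound 2 except in one place: fluoro in place of dimethylamino on an aromatic carbon. Thus the 4-(dimethylamino)phenyl of compound 2 becomes the 4-fluorophenyl of compound 3. Going by the values given here, no measured pair shows this change, so its size in this assay can only be judged roughly. Starting from compound 2 at 400 nM, a moderately weaker result, with a higher number, is expected, although a result within the usual scatter remains possible. The estimated change is a 3.8-fold higher number from compound 2 to compound 3 (0.57 log units; beyond the scatter). For compound 3 the expected value is 1500 nM, with an estimated range of 300 nM to 10000 nM.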

Compound 3, half-maximal inhibitory concentration: > 50000 nM
Compound 3 ended at the assay's limit (the forecaster's own chance of this, stated with the estimate: 10%); at least 33-fold (1.52 log units) between middle value and limit.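

Fluoro in place of dimethylamino on this aromatic ring gives an at least 120-fold higher number from compound 2 to compound 3 (2.09 log units; beyond the scatter) in this assay, so the group at this one position has a very large effect on the read-out. An aromatic ring at this place is therefore not enough by itself: the 4-fluorophenyl of compound 3 does not keep the activity seen with the 4-(dimethylamino)phenyl of compound 2. Compound 3 gives a limit of the assay and not an exact number, so the real size of the step stays unknown: the limit of > 50000 nM in this assay, at which 2 of the 3 values shown sit.

On these data alone, it remains open whether dimethylamino is unusual at this position, or whether a methoxy group, a hydroxyl or a primary amine would also give a low number. A plain phenyl ring without any such group would show how much of the difference depends on the group itself.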